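The source may hold more compounds than are shown below. What is called first, only, known or untested is meant among the compounds shown, and "the series" means these compounds.

Three amides on the shared core of compound 1 `CCCCNC(=O)c1c(O)c2cccnc2n(-c2ccccc2)c1=O` have numbers in a functional assay on the whole organism for inhibition, with Rattus norvegicus as the target, read by cytopathic effect and paw edema, at a dose of 100 mg/kg by the oral route; on this read-out lower numbers stand for less inhibition and higher numbers for more inhibition at the one dose given (going by the name of the read-out). Compound 1 gives 20.4%, compound 2 `O=C(NCc1ccccc1)c1c(O)c2cccnc2n(-c2ccccc2)c1=O` gives 11.3%, and compound 3 `O=C(NN1CCOCC1)c1c(O)c2cccnc2n(-c2ccccc2)c1=O` gives -26.2%, the lowest of the three; the step of a number 37.5 percentage points lower from compound 2 to compound 3 (beyond the scatter) separates it from its nearest neighbour, and the step of a number 46.6 percentage points lower from compound 1 to compound 3 (beyond the scatter) is larger still. Compound 4 `COc1cccc(NC(=O)c2c(O)c3cccnc3n(-c3ccccc3)c2=O)c1` differs from compound 3 in one place: 3-methoxyphenyl in place of morpholin-4-yl on an amide-type nitrogen. For the measured compounds named here, both measured steps that brought morpholin-4-yl onto the amide-type nitrogen lowered the number well beyond the scatter, so taking it away is expected to raise it by a comparable amount; an aromatic ring one carbon out in compound 2 gave 11.3%, while an aromatic ring directly on the amide-type nitrogen has no precedent here. The expected step is a number 41.2 percentage points higher from compound 3 to compound 4 (beyond the scatter). Compound 4 is therefore estimated at 15%, within -10% to 40%.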

Compound 4, a percentage reported as inhibition, in the whole organism at one dose (the size of the read-out at that dose, not a potency): 20.7%
For compound 4 the middle estimate is 5.7 percentage points below the measured one, and the stated range covers the measured number.
By their numbers in this assay, from the lowest: compound 3; then compounds 2, 1 and 4 (each within the scatter of the next).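

Read in this assay, the step of a number 46.9 percentage points higher from compound 3 to compound 4 (beyond the scatter) shows that a six-membered ring on the amide-type nitrogen does not by itself give the low number of compound 3, since the aromatic carbon ring of 3-methoxyphenyl does not. The steps of a number 9.4 percentage points higher from compound 2 to compound 4 (within the scatter) and a number 0.3 percentage points higher from compound 1 to compound 4 (within the scatter) leave an aromatic ring directly on this nitrogen indistinguishable from benzyl or butyl. No measured evidence bears on the reason for these differences.

Open, on these data alone, is what the methoxy group contributes, which a plain phenyl would test. Also open, as far as these compounds go, is whether piperidin-1-yl would track with morpholin-4-yl.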